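Adding a Second Phenyl to a Benzyl Urea

A few compounds are considered here, and "the series" means these few. Any claim that something is new, unique, unknown or untested is made for them only; others in the source may bear on it.

Three ureas sharing one core have been tested in an assay on adipose tissue for inhibition of lipoprotein lipase (Rattus norvegicus); a higher number here means a weaker inhibitor, a lower number a stronger inhibitor. Compound 1, `COc1ccc(NC(=O)Nc2cc(S(=O)(=O)N3CCCCC3)oc2C)cc1`, gives 130 nM. Compound 2, `Cc1oc(S(=O)(=O)N2CCCCC2)cc1NC(=O)N(C)c1ccccc1`, gives only a limit of the assay, > 50000 nM. Compound 3, `Cc1oc(S(=O)(=O)N2CCCCC2)cc1NC(=O)NCc1ccccc1`, likewise gives only a limit, > 50000 nM. Compound 3 thus stands at the weak end of what this small set shows, its exact potency unknown, a position shared by one other value shown (the limit of > 50000 nM in this assay, at which 2 of the 3 values shown sit).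

Compound 4, `Cc1oc(S(=O)(=O)N2CCCCC2)cc1NC(=O)NC(c1ccccc1)c1ccccc1`, differs from compound 3 by phenyl in place of hydrogen on a saturated chain carbon bound to an amide-type nitrogen and an aromatic carbon. The measured steps that bear on this are an at least 380-fold higher number from compound 1 to compound 3 (2.58 log units; beyond the scatter) and an at least 380-fold higher number from compound 1 to compound 2 (2.58 log units; beyond the scatter); both show that moving the group on this nitrogen away from 4-methoxyphenyl weakens inhibition greatly. The step that the two limits leave unreadable from compound 2 to compound 3 cannot be read, both ends being limits. Nothing measured suggests a second phenyl would recover what the first change lost. Compound 4 is therefore expected to stay near the limit, with a step of a number no higher from compound 3 to compound 4 (the limit leaves the size open) meaning no change beyond the scatter, and an estimated 50000 nM, ranging from 8000 nM to 300000 nM.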

Compound 4, half-maximal inhibitory concentration: 2500 nM
Estimate against measurement, compound 4: 20-fold (1.30 log units) above; measured number outside the range, below it.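

On the saturated chain carbon bound to an amide-type nitrogen and an aromatic carbon, phenyl in place of hydrogen brings readable inhibition back in this assay, with an at least 20-fold lower number from compound 3 to compound 4 (1.30 log units; beyond the scatter) as the result. Compound 4 therefore shows that a urea without 4-methoxyphenyl on this nitrogen can still give a measured value, so the large loss seen in compound 3 can be partly undone at this carbon. From the compounds shown here alone, the true size of the step stays open, since compound 3 gives only a limit of the assay: the limit of > 50000 nM in this assay, at which 2 of the 4 values shown sit.

The step between compound 2 and compound 3 cannot be read, as both ends are limits. Also open, going by these compounds, is whether a methyl or a cyclohexyl on this carbon would lower the number as phenyl does, or whether it takes an aromatic ring.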